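The compounds below may be only part of what the source reports. "The series", "measured", "known", "first", "only" and "open" are said of these compounds alone.

Compounds so far:
compound 1 `O=C1C=C(Nc2cccc(F)c2)C(=O)c2c1nc1n2[C@H]2OC[C@@H](O)[C@H]2OC1` – 5500 nM
compound 2 `O=C1C=C(Nc2ccc(C(F)(F)F)cc2)C(=O)c2c1nc1n2[C@H]2OC[C@@H](O)[C@H]2OC1` – > 4000 nM

In a functional assay on MCF7 cells (Homo sapiens) for inhibition, read by sulforhodamine B assay (on this read-out lower numbers stand for stronger inhibition and higher numbers for weaker inhibition), compound 1 gives 5500 nM. For compound 2 only a limit is recorded, > 4000 nM, so its place on the scale is not fixed. Within the data shown here, the one measured step, a step that the limit leaves unreadable from compound 1 to compound 2, is therefore unreadable (the limit of > 4000 nM in this assay, at which 1 of the 2 values shown sits). Compound 3 `COc1cccc(NC2=CC(=O)c3nc4n(c3C2=O)[C@H]2OC[C@@H](O)[C@H]2OC4)c1` carries 3-methoxyphenyl in place of 4-(trifluoromethyl)phenyl on an amine nitrogen. Among the measured compounds shown here, no measured step bears on this change, and compound 2 itself stands at a limit. The estimated step for compound 3, a step that the limit leaves unreadable from compound 2 to compound 3, is therefore expected to carry no direction beyond the scatter. Compound 3 is expected at about 5000 nM, within 1500 nM to 20000 nM.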

Compound 3, half-maximal inhibitory concentration: > 4000 nM
Compound 3 gave a limit, no number; the forecaster's own chance of this, stated with the estimate: 40%; the middle value does not contradict the limit.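

Compound 3 gives > 4000 nM in this assay, a limit and not a number, so no step among compound 1, compound 2 and compound 3 can be read: the limit of > 4000 nM in this assay, at which 2 of the 3 values shown sit.

Left open is whether 3-fluorophenyl, 4-(trifluoromethyl)phenyl and 3-methoxyphenyl differ at all in this assay.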